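Removing the methyl from compound 3: an expectation

The compounds below may be only part of what the source reports. "The series", "measured", "known", "first", "only" and "open" are said of these compounds alone.

Working notes on a small set of indole-type compounds measured in a functional assay on MCF7 cells (Homo sapiens) for cytotoxicity, read by MTT assay, with a stated time of 72 h; a lower number here means a stronger inhibitor, a higher number a weaker inhibitor.

Compound 1 `COc1ccc2[nH]c(-c3ccc[nH]3)c(C3CC(=O)NC3=O)c2c1` gives 19000 nM in this assay. Compound 2 `COc1ccc2[nH]c(-c3ccc[nH]3)cc2c1` gives 84000 nM. Going by the values given here, the single one-place step available, a 4.4-fold higher number from compound 1 to compound 2 (0.65 log units; beyond the scatter), concerns hydrogen in place of 2,5-dioxopyrrolidin-3-yl on an aromatic carbon and says nothing about a methyl.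

Compound 3 `Cc1ccc2[nH]c(-n3cccn3)c(C3=C(Br)C(=O)NC3=O)c2c1` gives 15000 nM, the lowest of the three numbers, though its gap to compound 1 lies within the scatter, so no order between these two is claimed; only compound 2 stands clearly apart from it.

Compound 4 `O=C1NC(=O)C(c2c(-n3cccn3)[nH]c3ccccc23)=C1Br` differs from compound 3 by hydrogen in place of methyl on an aromatic carbon, the hydrogen taking the methyl's place on an aromatic carbon of a six-membered aromatic ring of carbon only, part of a fused system of two rings. Among the compounds with values here, no measured step touches this change, so the expectation is a step of no more than the scatter in either direction, no change at the digits printed from compound 3 to compound 4 (within the scatter). Compound 4 is therefore estimated at 15000 nM, with a range from 6000 nM to 40000 nM.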

Compound 4, half-maximal inhibitory concentration: 27000 nM
Compound 4: the middle estimate sits 1.8-fold (0.26 log units) below what was measured, and the stated range covers the measured number.
By their numbers in this assay, from the lowest: compounds 3, 1 and 4 (each within the scatter of the next); then compound 2.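

In this assay, going by these compounds alone, hydrogen in place of methyl gives a 1.8-fold higher number from compound 3 to compound 4 (0.26 log units; within the scatter), the first reading at this aromatic carbon of the six-membered aromatic ring of carbon only. On the core of compound 3, the methyl can therefore be removed without a change that stands clear of the scatter, and no order is claimed between the two compounds. Nothing available explains this reading or links it to any property of the methyl.

On these data alone, whether an amine, a carboxylic acid or a longer chain on this carbon would move the number beyond the scatter remains open. As far as these compounds go, it is also open whether the same change would read alike with the 2,5-dioxopyrrolidin-3-yl group of compound 1 in place of the bromine-bearing ring of compound 3.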